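The source may hold more compounds than are shown below. What is called first, only, known or untested is meant among the compounds shown, and "the series" means these compounds.

Among the measured compounds shown here, compound 1 `CNC(=O)CC1CCc2cc(OC)c(OC)cc21` in a functional assay on the whole organism (strain Wistar) for inhibition, with Rattus norvegicus as the target, read by paw edema, with stated times of 60 min and 6 h, at a dose of 100 mg/kg by the oral route (on this read-out lower numbers stand for less inhibition and higher numbers for more inhibition at the one dose given (going by the name of the read-out)), gives 24.1%, the lower of the two numbers measured so far. For the measured compounds named here, compound 2 `COc1cc2c(cc1OC)C(CC(=O)NCc1ccccc1)CC2` in this assay gives 30.6%, and the one measured step, a number 6.5 percentage points higher from compound 1 to compound 2 (within the scatter), lies within the scatter, so the two compounds cannot be ordered. Compound 3 `COc1cc2c(cc1OC)C(CC(=O)N1CCNCC1)CC2` has not been measured. It differs from compound 1 at the amide end of the chain: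

piperazin-1-yl in place of methylamino on a carbonyl carbon

Going by the values given here, the only measured step that bears on this is the change at the amide nitrogen from compound 1 to compound 2, which stayed within the scatter. No step with a ring entering at the carbonyl carbon has been measured, so nothing shown argues for a move beyond the scatter in either direction. For compound 3 an expected step of a number 0.9 percentage points higher from compound 1 to compound 3 (within the scatter) in this assay is therefore assumed. Compound 3 is estimated at 25% in this assay, with a range from 10% to 42%.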

Compound 3, a percentage reported as inhibition, in the whole organism at one dose (the size of the read-out at that dose, not a potency): 33.3%
For compound 3 the middle estimate is 8.3 percentage points below the measured one; measured number inside the range.
By their numbers in this assay, from the lowest: compounds 1, 2 and 3 (each within the scatter of the next).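

In this assay, a ring on the carbonyl carbon now has a reading: the six-membered piperazin-1-yl gives a number 9.2 percentage points higher from compound 1 to compound 3 (within the scatter) and, set against benzylamino, a number 2.7 percentage points higher from compound 2 to compound 3 (within the scatter). Methylamino, benzylamino and piperazin-1-yl therefore cannot be told apart at this position, whether the entering group is an open chain or a non-aromatic ring with two hetero atoms. No measured information is available to explain these readings.

On these data alone, it remains open whether any group on this carbonyl carbon, such as morpholin-4-yl or a hydroxyl that would make a carboxylic acid, would separate from these three by more than the scatter. The methoxy groups are the same in all three compounds, so replacing them with hydroxy groups, or using a longer chain to the carbonyl, remains unaddressed.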